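Tosylate of compound 3 in the cytotoxicity series

The compounds below may be only part of what the source reports. "The series", "measured", "known", "first", "only" and "open" are said of these compounds alone.

Compound 3 `Cc1ccc(-c2cn(C[C@H]3c4c(ccc(O)c4C)[C@@H]4CC[C@@]5(C)C[C@]43CC5=O)nn2)cc1` carries a free hydroxy group on its aromatic ring. In a functional assay on SMMC-7721 cells (Homo sapiens) for cytotoxicity, read by MTT assay, with a stated time of 4 days (on this read-out higher numbers stand for weaker inhibition and lower numbers for stronger inhibition), compound 3 gives only a limit, > 20000 nM, so no number is known for it. Compound 1 `Cc1ccc(S(=O)(=O)Oc2ccc3c(c2C)[C@H](Cn2cc(-c4ccccc4)nn2)[C@@]24CC(=O)[C@@](C)(CC[C@@H]32)C4)cc1` and compound 2 `Cc1ccc(S(=O)(=O)Oc2ccc3c(c2C)[C@H](Cn2cc(-c4ccc(Cl)cc4)nn2)[C@@]24CC(=O)[C@@](C)(CC[C@@H]32)C4)cc1` already carry the ((4-methylphenyl)sulfonyl)oxy group, with other aryl groups on the triazole. In this assay compound 1 gives a limit, > 20000 nM. In this assay compound 2 also gives a limit, > 20000 nM. The step that the two limits leave unreadable from compound 1 to compound 2 therefore has no readable size. Compound 4 `Cc1ccc(-c2cn(C[C@H]3c4c(ccc(OS(=O)(=O)c5ccc(C)cc5)c4C)[C@@H]4CC[C@@]5(C)C[C@]43CC5=O)nn2)cc1` differs from compound 3 by (4-methylphenyl)sulfonyl in place of hydrogen on an oxygen on an aromatic ring. For the measured compounds named here, no measured step covers this change directly; the nearest evidence is the limit of > 20000 nM in this assay, at which 3 of the 3 values shown sit, which places every value shown at the same limit, so no step has been sized at all. Because all values sit at the limit of > 20000 nM in this assay, at which 3 of the 3 values shown sit, compound 4 is expected to stay at the limit, and the step that the limit leaves unreadable from compound 3 to compound 4 is expected to be unreadable rather than beyond the scatter. The estimate for compound 4 is 30000 nM, with a range from 15000 nM to 100000 nM.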

Compound 4, half-maximal inhibitory concentration: > 20000 nM
Compound 4: a limit, no number; the forecaster's own chance of this, stated with the estimate: 85%; the middle value does not contradict the limit.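

In this assay compound 4 gives only a limit, > 20000 nM, so the steps to it from compound 1, compound 2 and compound 3 cannot be read. The compounds shown leave open which change, if any, would give a measurable value, since all sit at one limit: the limit of > 20000 nM in this assay, at which 4 of the 4 values shown sit.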